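A few compounds are considered here, and "the series" means these few. Any claim that something is new, unique, unknown or untested is made for them only; others in the source may bear on it.

Of the compounds shown here, two have been measured in a functional assay on NCI-H522 cells (Homo sapiens) for cytotoxicity, read by sulforhodamine B assay, with a stated time of 48 h; a lower number here means a stronger inhibitor of growth, a higher number a weaker inhibitor of growth. Compound 1 `ClCc1ccccc1Cn1cnc2c(Cl)nc(Cl)nc21` gives 1990 nM, and compound 2 `ClCc1cccc(Cn2cnc3c(Cl)ncnc32)c1` gives 66100 nM. Compound 1 thus has the lower of the two numbers; the gap to compound 2 is beyond the scatter, so compound 1 is the stronger growth inhibitor of the pair.

The next compound, compound 3 `Nc1nc(Cl)c2ncn(Cc3ccccc3CCl)c2n1`, differs from compound 1 in one place: amino in place of chloro on an aromatic carbon, on the shared core of compound 1. For the measured compounds named here, no pair of measured compounds differing in this one place is available, so the size of this step has no precedent here. A modest shift toward a higher number is expected for the step from compound 1 to compound 3, a 2.0-fold higher number from compound 1 to compound 3 (0.30 log units; within the scatter), within or only slightly beyond the scatter. Compound 3 is therefore estimated at 4000 nM, with a range from 1000 nM to 16000 nM.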

Compound 3, concentration for total growth inhibition: 9330 nM
Estimate against measurement, compound 3: 2.3-fold (0.37 log units) below; low and high end bracket the measured number.
By their numbers in this assay, from the lowest: compound 1; then compound 3; then compound 2.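

This position, on an aromatic carbon between two ring nitrogen atoms, now has its first measured change: in this assay, amino in place of chloro gives a 4.7-fold higher number from compound 1 to compound 3 (0.67 log units; beyond the scatter). Chloro and amino are therefore distinguishable at this carbon, although the amino compound still has a measured growth-inhibition value in this assay. No supporting data on the compounds shown bear on the origin of this shift.

Still open, from the compounds shown here alone, is how a methoxy group or a dimethylamino group on this carbon would compare with chloro and amino. A single step also cannot show whether the same change would have a similar size with a different group elsewhere on the shared core.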